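The source may hold more compounds than are shown below. What is called first, only, known or untested is meant among the compounds shown, and "the series" means these compounds.

In a functional assay on A549 cells (Homo sapiens) for inhibition, read by sulforhodamine B assay, with a stated time of 72 h (on this read-out lower numbers stand for stronger inhibition of growth and higher numbers for weaker inhibition of growth), compound 1 (`CNC(=O)/C=C/c1ccncc1-c1ccc2ccccc2c1`) gives 6620 nM. Compound 2 (`CNC(=O)/C=C/c1ccncc1-c1ccc2cc[nH]c2c1`) gives 7840 nM and compound 3 (`CCOC(=O)/C=C/c1ccncc1-c1ccc2cc[nH]c2c1`) gives 5740 nM. All three numbers lie within the usual scatter of one another, so compound 1 stands level with both and no order can be read among them.

Compound 4 (`NC(=O)/C=C/c1ccncc1-c1ccc2ccccc2c1`) differs from compound 1 by one small edit: hydrogen in place of methyl on an amide-type nitrogen. Among the compounds with values here, no measured pair shows this exact change. The closest evidence is a different edit on a carbonyl carbon, ethoxy in place of methylamino, which gave a 1.4-fold lower number from compound 2 to compound 3 (0.14 log units; within the scatter). Within the data shown here, with only that one step to go on, no shift beyond the scatter is expected in this assay, and the direction cannot be told. The step expected is a 1.0-fold lower number from compound 1 to compound 4 (0.01 log units; within the scatter). The estimate for compound 4 is 6500 nM, with an expected range from 3000 nM to 14000 nM.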

Compound 4, concentration for 50% growth inhibition: > 10000 nM
Compound 4: only a limit was reported; the forecaster's own chance of this, stated with the estimate: 5%; middle value at least 1.5-fold (0.18 log units) from the limit.
By their numbers in this assay, from the lowest: compounds 3, 1 and 2 (each within the scatter of the next). At a limit, above all of these: compound 4.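

In this assay, as far as these compounds go, hydrogen in place of methyl on the amide-type nitrogen gives an at least 1.5-fold higher number from compound 1 to compound 4 (0.17 log units; that floor lies within the scatter), so the true size of this step is still unknown. Within the data shown here, the earlier compounds changed only the whole group on the carbonyl carbon, ethoxy in place of methylamino, and that step stayed within the scatter; this pair is the first to test the methyl alone, and it suggests that this small group may matter, although the floor of the step does not clear the scatter. For compound 4 only a limit was reported, not a number: the limit of > 10000 nM in this assay, at which 1 of the 4 values shown sits.

From the compounds shown here alone, it remains open whether a longer chain on that nitrogen, such as ethyl, would stay level with compound 1. Also open, going by these compounds, is how a carboxylic acid on the carbonyl carbon would compare with the ethyl ester of compound 3.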